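A few compounds are considered here, and "the series" means these few. Any claim that something is new, unique, unknown or untested is made for them only; others in the source may bear on it.

Three compounds share one core and differ only in the ring attached to the amide-type nitrogen: compound 1 `COc1ccc(NC(=O)CN2CCN(S(=O)(=O)N3CCC(C)CC3)CC2)cc1`, compound 2 `CC1CCN(S(=O)(=O)N2CCN(CC(=O)Nc3ccc(Cl)cc3)CC2)CC1` and compound 3 `CC1CCN(S(=O)(=O)N2CCN(CC(=O)Nc3cccc(F)c3)CC2)CC1`. In an assay on HEK293 cells for activation of potassium channel subfamily T member 1 (Homo sapiens), read by thallium flux (on this read-out lower numbers stand for an effect already at smaller amounts and higher numbers for an effect only at larger amounts of compound), compound 1 reaches only the limit of the assay, > 10000 nM. Compound 2 likewise reaches only the limit, > 10000 nM. Among the compounds with values here, compound 3 is the one compound with a measured number, 4600 nM. The exchange of the ring gives an at least 2.1-fold lower number from compound 1 to compound 3 (0.33 log units; beyond the scatter) and an at least 2.1-fold lower number from compound 2 to compound 3 (0.33 log units; beyond the scatter), while a step that the two limits leave unreadable from compound 1 to compound 2.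

Compound 4 `CC1CCN(S(=O)(=O)N2CCN(CC(=O)Nc3cc(Cl)ccc3F)CC2)CC1` carries a further change, (5-chloro-2-fluorophenyl in place of 3-fluorophenyl on an amide-type nitrogen). Within the data shown here, no measured step adds a chloro while keeping a fluoro, and the chloro-bearing compound 2 sits at the limit of > 10000 nM in this assay, at which 2 of the 3 values shown sit. A step of a 1.3-fold higher number from compound 3 to compound 4 (0.12 log units; within the scatter) is therefore expected, and compound 4 is estimated at 6000 nM, between 2000 nM and 20000 nM.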

Compound 4, half-maximal effective concentration: 3800 nM
Estimate against measurement, compound 4: 1.6-fold (0.20 log units) above; the range from low to high includes it.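

In this assay, 5-chloro-2-fluorophenyl on the amide-type nitrogen gives a 1.2-fold lower number from compound 3 to compound 4 (0.08 log units; within the scatter), so this position takes the added chloro without a change beyond the scatter. The same ring gives an at least 2.6-fold lower number from compound 2 to compound 4 (0.42 log units; beyond the scatter) and an at least 2.6-fold lower number from compound 1 to compound 4 (0.42 log units; beyond the scatter). A chloro on this ring therefore does not by itself leave a compound where compound 2 stands, at a limit of the assay: the limit of > 10000 nM in this assay, at which 2 of the 4 values shown sit.

The compounds shown leave open whether the fluoro is needed once the chloro is present. They also leave open how a nitrile or a trifluoromethyl group would read in place of the chloro.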